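A few compounds are considered here, and "the series" means these few. Any claim that something is new, unique, unknown or untested is made for them only; others in the source may bear on it.

Compound 2 `COCCCOc1ccc(S(=O)(=O)Nc2ccc(C(=O)CSC(C)=O)cn2)cc1` gives 5300 nM in a functional assay on HCT-116 cells (Homo sapiens) for cytotoxicity (on this read-out lower numbers stand for an effect already at smaller amounts and higher numbers for an effect only at larger amounts of compound), and stands at the upper end of the two numbers shown, though within the scatter of compound 1. Compound 1 `CC(=O)SCC(=O)c1ccc(NS(=O)(=O)c2ccc(OC3CCCN(C)C3)cc2)nc1` gives 3700 nM in this assay. Compound 3 `CC(=O)SCC(=O)c1ccc(NS(=O)(=O)c2ccc(OC3CCN(C)CC3)cc2)nc1` carries 1-methylpiperidin-4-yl in place of 3-methoxypropyl on an oxygen on an aromatic ring. Among the measured compounds shown here, the one step at hand that bears on this change is a 1.4-fold higher number from compound 1 to compound 2 (0.16 log units; within the scatter), which ran the other way and stayed within the scatter. On that basis the step from compound 2 to compound 3 is expected to be small, a 1.3-fold lower number from compound 2 to compound 3 (0.12 log units; within the scatter), tending if anything toward a lower number. Compound 3 is therefore estimated at 4000 nM, between 1500 nM and 11000 nM.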

Compound 3, half-maximal effective concentration: 180 nM
Compound 3: middle estimate off by 22-fold (1.35 log units), on the high side; the whole stated range lies above it.
By their numbers in this assay, from the lowest: compound 3; then compounds 1 and 2 (each within the scatter of the next).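

In this assay the 1-methylpiperidin-4-yl group on this oxygen stands clearly apart, with a 29-fold lower number from compound 2 to compound 3 (1.47 log units; beyond the scatter) and a 21-fold lower number from compound 1 to compound 3 (1.31 log units; beyond the scatter) as the two large steps, whereas the earlier pair stayed within the scatter. A piperidine ring alone therefore does not mark the gain: compound 1 also carries one, and the place of attachment on that ring separates it from compound 3. No measured evidence bearing on the reason is at hand. As far as these compounds go, it remains open how a piperidin-4-yl without the methyl, a 1-ethylpiperidin-4-yl or a 2-(dimethylamino)ethyl chain would fare on the same oxygen.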